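Vero cell viability notes: chloro to hydroxy on the aryl ring

The source may hold more compounds than are shown below. What is called first, only, known or untested is meant among the compounds shown, and "the series" means these compounds.

Of the compounds shown here, two have numbers so far. Compound 1 `COc1ccc(C2SCC(=O)N2CCN2CCCCC2)cc1` gives 87% in an ADME assay on Vero cells (Chlorocebus sabaeus) for cytotoxicity, read by neutral red uptake, tested at 197 ug/mL; on this read-out higher numbers stand for a weaker effect at the one concentration tested and lower numbers for a stronger effect. Compound 2 `O=C1CSC(c2cccc(Cl)c2)N1CCN1CCCCC1` gives 77% in this assay. Compound 2 has the lowest of the two numbers; its nearest neighbour, compound 1, sits a little higher, and the two values lie within the scatter of each other, so no order between them can be claimed.

Compound 3 `O=C1CSC(c2cccc(O)c2)N1CCN1CCCCC1` is still to be measured in this assay. It differs from compound 2 in one place: hydroxy in place of chloro on an aromatic carbon. Among the compounds with values here, no measured pair of this kind exists, so the size of the step rests on the change alone.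

Compound 3 is expected to move toward a weaker effect, by a number 9 percentage points higher from compound 2 to compound 3 (within the scatter), a step that may stay within the scatter. In this assay compound 3 is estimated at 86%, with a range from 70% to 98%.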

Compound 3, a percentage reported as activity, at one concentration (the size of the read-out at that concentration, not a potency): 100%
Compound 3: the middle estimate sits 14 percentage points below what was measured, and the stated range ends below it.
By their numbers in this assay, from the lowest: compounds 2 and 1 (each within the scatter of the next); then compound 3.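

In this assay, within the data shown here, hydroxy in place of chloro on this aromatic carbon gives a number 23 percentage points higher from compound 2 to compound 3 (beyond the scatter) and so provides the first step that lies beyond the scatter. The change from 3-chlorophenyl to 3-hydroxyphenyl therefore moves the read-out toward a weaker effect at the one concentration tested, which shows that the group at this position can matter on this core. No supporting measurement speaks to why the step has this direction or size.

One pair cannot show whether the step is specific to hydroxy or would also appear with an amine or a carboxylic acid on the same carbon. From the compounds shown here alone, whether the same change gives a similar step elsewhere on the aromatic ring also remains open.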